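Cyano and methyl changes in an antiproliferative anilinopyrimidine series

A few compounds are considered here, and "the series" means these few. Any claim that something is new, unique, unknown or untested is made for them only; others in the source may bear on it.

Three compounds share an anilinopyrimidine core carrying an acrylamide and a basic side chain. Compound 2 `CC/C=C\C(=O)Nc1cc(Nc2nccc(-c3cn(C)c4ccccc34)n2)c(OC)cc1N(C)CCN(C)C` gives 6670 nM in a functional assay on HepG2 cells (Homo sapiens) for antiproliferative activity, read by MTT assay, with a stated time of 72 h; on this read-out lower numbers stand for stronger inhibition and higher numbers for weaker inhibition. Compound 1 `COc1cc(N(C)CCN(C)C)c(NC(=O)/C=C\C(C)C)cc1Nc1nccc(-c2cn(C)c3ccccc23)n1` differs from it by methyl in place of hydrogen on a saturated chain carbon bound to a double-bonded chain carbon and a saturated chain carbon; in this assay compound 1 gives 4390 nM, and the step of a 1.5-fold lower number from compound 2 to compound 1 (0.18 log units; within the scatter) is small. Compound 3 `CC/C=C\C(=O)Nc1cc(Nc2ncc(C#N)c(-c3cn(C)c4ccccc34)n2)c(OC)cc1N(C)CCN(C)C` differs from compound 2 by cyano in place of hydrogen on an aromatic carbon; in this assay compound 3 gives 1360 nM, and the step of a 4.9-fold lower number from compound 2 to compound 3 (0.69 log units; beyond the scatter) is the only one here that exceeds the scatter, so compound 3 stands as the lowest number of the three measured.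

Compound 4 `COc1cc(N(C)CCN(C)C)c(NC(=O)/C=C\C(C)C)cc1Nc1ncc(C#N)c(-c2cn(C)c3ccccc23)n1` is not yet measured. Relative to compound 3 it carries methyl in place of hydrogen on a saturated chain carbon bound to a double-bonded chain carbon and a saturated chain carbon, the same change that separates compound 1 from compound 2, at the same place. The cores of the two pairs differ by cyano in place of hydrogen on an aromatic carbon.

Among the measured compounds shown here, with only one prior instance, the expectation for compound 4 rests on the step of a 1.5-fold lower number from compound 2 to compound 1 (0.18 log units; within the scatter); the estimated step of a 1.4-fold lower number from compound 3 to compound 4 (0.13 log units; within the scatter) is expected to be of similar size and to stay within the scatter. Compound 4 is therefore expected to give about 1000 nM in this assay, with a plausible range from 450 nM to 2200 nM. Whether the cyano-bearing core alters the effect of the methyl cannot be judged from the compounds shown.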

Compound 4, half-maximal inhibitory concentration: 1810 nM
Compound 4: middle estimate off by 1.8-fold (0.26 log units), on the low side; measured number inside the range.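

In this assay, among the compounds shown here, the methyl on the saturated chain carbon bound to a double-bonded chain carbon and a saturated chain carbon gives a 1.3-fold higher number from compound 3 to compound 4 (0.12 log units; within the scatter) on the cyano-bearing core, and the gap to the earlier step on the core without cyano stays within the scatter: the same change on two cores in this assay, a 1.5-fold lower number (0.18 log units; within the scatter) from compound 2 to compound 1 and a 1.3-fold higher number (0.12 log units; within the scatter) from compound 3 to compound 4, 2.0-fold (0.31 log units) apart, within the scatter of two such steps The cyano in place of hydrogen on the aromatic carbon, read on the methyl-bearing pair, gives a 2.4-fold lower number from compound 1 to compound 4 (0.38 log units; beyond the scatter), which again lies beyond the scatter, and its two readings do not differ beyond the scatter: the same change on two cores in this assay, a 4.9-fold lower number (0.69 log units; beyond the scatter) from compound 2 to compound 3 and a 2.4-fold lower number (0.38 log units; beyond the scatter) from compound 1 to compound 4, 2.0-fold (0.31 log units) apart, within the scatter of two such steps Within these four compounds, both changes therefore carry from one core to the other without a detectable shift, but with only two pairs per change this does not show that the steps are identical on both cores or that the methyl step has no effect, and the opposite directions printed for the methyl steps cannot be read as a reversal.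

Going by these compounds, it remains open whether the same carry-over would hold for a larger group at that chain carbon, such as tert-butyl or phenyl, or for chlorine or trifluoromethyl in place of the cyano on the aromatic carbon. The compounds shown also leave open whether these steps hold in any cell line other than HepG2.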